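The source may report more compounds than this note shows. Statements on the series, on what has been measured and on what is new or still open speak of the compounds shown alone.

Of the compounds shown here, three have been tested in an assay on PEO1 cells for inhibition of Retinaldehyde dehydrogenase 3 (Homo sapiens), read by flow cytometry, with a stated time of 30 min, tested at 1 uM; a higher number here means more inhibition at the concentration tested (going by the name of the read-out), a lower number less inhibition. Compound 1 `CC(Sc1nc2nn(CC3COC3)cc2c(=O)n1-c1ccccc1)c1ccccc1` gives 87%, compound 2 `CC(Sc1nc2c(cnn2C)c(=O)n1-c1ccccc1)c1ccccn1` gives 97%, and compound 3 `O=c1c2cn(C3COC3)nc2nc(SCc2cccc(F)c2)n1-c1ccccc1` gives 50%. The readings of compound 2 and compound 1 lie within the usual scatter of each other, so the two cannot be told apart; compound 3, however, sits clearly lower than both, and its distance from compound 2 is well beyond the scatter.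

Compound 4 `Cn1ncc2c(=O)n(-c3ccccc3)c(SCc3cccc(F)c3)nc21` has not yet been measured in this assay. It shares the core of compound 2 and differs from it at a single spot: 3-fluorobenzyl in place of 1-(pyridin-2-yl)ethyl on a sulfur The group that enters, 3-fluorobenzyl on a sulfur, is also present in compound 3, although compound 3 differs from compound 4 in another part of the molecule as well.

No measured pair isolates exactly this change, so the expectation rests on what is shown. Compound 3, which carries the same 3-fluorobenzyl on a sulfur, gives 50%, while compound 2 gives 97%. Taking the two branched groups of compound 1 and compound 2 as the stronger readings, a downward step from compound 2 to compound 4 is expected, estimated at a number 32 percentage points lower from compound 2 to compound 4 (beyond the scatter), beyond the scatter. Compound 4 is therefore expected to give about 65% in this assay, somewhere between 35% and 90%.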

Compound 4, a percentage reported as inhibition, at one concentration (the size of the read-out at that concentration, not a potency): 3%
Beside the measured number, compound 4's estimate is 62 percentage points above it; the whole stated range lies above it.
By their numbers in this assay, from the lowest: compound 4; then compound 3; then compounds 1 and 2 (each within the scatter of the next).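

In this assay, replacing 1-(pyridin-2-yl)ethyl with 3-fluorobenzyl on the sulfur, with the rest of the molecule unchanged, gives a number 94 percentage points lower from compound 2 to compound 4 (beyond the scatter). For the compounds shown here, this is the first direct reading of this position, and it shows that the group on the sulfur can by itself separate a compound with strong inhibition at the tested concentration from one with very little, even though both groups contain a six-membered aromatic ring and have the same heavy-atom count. No measurement here explains the size of this drop.

The step changes several features at once, since the ring nitrogen is lost, a fluorine is gained and the branched ethyl link becomes a plain benzyl link, so a simple benzyl or a 1-phenylethyl group on the same core would be needed to show which of these matters. On these data alone, it also remains open how far the effect of 3-fluorobenzyl depends on the rest of the molecule, as compound 3, which carries that group with a different substituent on the shared core, gives 50%.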